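Compound 4: removing one methyl from compound 2

This account rests on a few compounds, and the source may have more. Where it says the series, first, only, none or still open, it means among the compounds named here.

In a functional assay on MDA-MB-435 cells (Homo sapiens) (a higher number here means a weaker inhibitor of growth, a lower number a stronger inhibitor of growth), compound 1 `Cc1ccnc2nc(-c3ccc(F)cc3)cc(O)c12` gives 2880 nM and compound 3 `Cc1cnc2nc(-c3ccc(F)cc3)cc(O)c2c1` gives 2630 nM. Compound 2 `COc1cccc(-c2cc(O)c3c(C)cc(C)nc3n2)c1` reads < 10 nM, which is a limit of the assay and not a number. Only that limit is known for compound 2, and the values of compound 1 and compound 3 lie far on the higher side of it.

Compound 4 `COc1cccc(-c2cc(O)c3c(C)ccnc3n2)c1` differs from compound 2 at one place hydrogen in place of methyl on an aromatic carbon, next to the ring nitrogen. For the measured compounds named here, no measured pair isolates this change. Going by the values given here, compound 1 at 2880 nM and compound 3 at 2630 nM also carry a single methyl on that ring, but their aryl group differs from the one compound 4 shares with compound 2, so they are a weak guide to its level.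

The expected change is an at least 3.0-fold higher number from compound 2 to compound 4 (0.47 log units; beyond the scatter), a moderate move towards weaker growth inhibition in this assay. For compound 4 the estimate is 30 nM, with an expected range of 8 nM to 250 nM.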

Compound 4, concentration for 50% growth inhibition: < 10 nM
Compound 4 gave a limit, no number; the forecaster's own chance of this, stated with the estimate: 25%; middle value at least 3.0-fold (0.47 log units) from the limit.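

Compound 4 reads < 10 nM in this assay, which is a limit of the assay and not a number. No step from compound 2 to compound 4 can be read, because both compounds sit at the same limit: the limit of < 10 nM in this assay, at which 2 of the 4 values shown sit.

The compounds shown leave open whether hydrogen in place of methyl on this aromatic carbon changes growth inhibition at all.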